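Benzothiophene to fluorophenyl amide in the piperidine series

A few compounds are considered here, and "the series" means these few. Any claim that something is new, unique, unknown or untested is made for them only; others in the source may bear on it.

Compound 1 `CC(C)[C@@H](NC(=O)c1cc2ccccc2s1)C(=O)N1CCC(c2ccc(Cl)cc2)CC1` gives 58 nM in an assay on THP-1 cells for displacement of a labelled ligand from C-C chemokine receptor type 1 (Homo sapiens) (on this read-out lower numbers stand for stronger inhibition and higher numbers for weaker inhibition), the lowest of the two numbers in hand. Compound 2 `CC(C)C(NC(=O)c1ccccc1)C(=O)N1CCC(c2ccc(F)cc2)CC1` gives 423 nM in this assay, a weaker result, though compound 2 differs from compound 1 in more than one place. Compound 3 `CC(C)[C@@H](NC(=O)c1cccc(F)c1)C(=O)N1CCC(c2ccc(Cl)cc2)CC1` is unmeasured; it differs from compound 1 as follows: 3-fluorophenyl in place of 1-benzothiophen-2-yl on a carbonyl carbon. Among the compounds with values here, no step between measured compounds is available, so the size of this change is judged from compound 2 alone. Compound 3 is expected to be weaker than compound 1, with an estimated step of a 4.3-fold higher number from compound 1 to compound 3 (0.63 log units; beyond the scatter). Compound 3 is estimated at 250 nM, within 90 nM to 700 nM.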

Compound 3, half-maximal inhibitory concentration: 24 nM
Beside the measured number, compound 3's estimate is 10-fold (1.02 log units) above it; the measured number lies below the stated range.
By their numbers in this assay, from the lowest: compound 3; then compound 1; then compound 2.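

In this assay, replacing 1-benzothiophen-2-yl on a carbonyl carbon with 3-fluorophenyl gives a 2.4-fold lower number from compound 1 to compound 3 (0.38 log units; beyond the scatter) and is a modest gain beyond the scatter. This position therefore does not depend on the five-membered aromatic ring or its sulfur, and a single six-membered aromatic ring of carbon only is enough here. No measurement at hand bears on the origin of this step.

On these data alone, it remains open whether the fluorine contributes to the step at all. A nitrile, a methoxy group or an amine on the same phenyl ring could show how much variation this position accepts.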